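A Methyl on the Aromatic Nitrogen of Compound 2

A few compounds are considered here, and "the series" means these few. Any claim that something is new, unique, unknown or untested is made for them only; others in the source may bear on it.

Compound 1 `Cn1cc(C(=O)N/N=C\c2cn(Cc3ccc(Cl)cc3)c3cc(F)ccc23)c2ccccc21` and compound 2 `COc1ccc(Cn2cc(/C=N\NC(=O)c3c[nH]c4ccccc34)c3ccc(F)cc32)cc1` have both been examined in a functional assay on LNCaP cells (Homo sapiens) for cytotoxicity; a higher number here means a weaker inhibitor, a lower number a stronger inhibitor. For compound 1 the assay reports only a limit, > 100000 nM. For compound 2 the assay likewise reports only a limit, > 100000 nM. Compound 2 therefore stands exactly where the other measured value stands, at the limit of > 100000 nM in this assay, at which 2 of the 2 values shown sit, and no order between the two can be read from what is shown.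

Compound 3 `COc1ccc(Cn2cc(/C=N\NC(=O)c3cn(C)c4ccccc34)c3ccc(F)cc32)cc1` has not yet been measured in this assay. It differs from compound 2 in one place: methyl in place of hydrogen on an aromatic nitrogen, that is, 1H-indol-3-yl becomes 1-methyl-1H-indol-3-yl on the shared core. Compound 1 carries that same methyl on its aromatic nitrogen and is also reported only as a limit in this assay. Among the measured compounds shown here, no measured step between compounds is available, so the expected change from compound 2 to compound 3 is estimated as none beyond the scatter, expressed as a step of a number no higher from compound 2 to compound 3 (the limit leaves the size open). Compound 3 is expected to give about 100000 nM, within a range from 30000 nM to 300000 nM, and most probably to be reported again only as a limit.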

Compound 3, half-maximal inhibitory concentration: 9600 nM
For compound 3 the middle estimate is 10-fold (1.02 log units) above the measured one; measured number below the stated range.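

In this assay methyl in place of hydrogen on the aromatic nitrogen brings an at least 10-fold lower number from compound 2 to compound 3 (1.01 log units; beyond the scatter), which shows that the read-out can respond to a change at this nitrogen of the 1H-indol-3-yl group. The methyl does not do this whatever the rest of the molecule carries: compound 1 has the same 1-methyl-1H-indol-3-yl group, and methoxy in place of chloro on an aromatic carbon brings an at least 10-fold lower number from compound 1 to compound 3 (1.01 log units; beyond the scatter), so among these compounds a measured number appears only where the methyl and the methoxy stand together. Compound 3 is thus the only one of the three with a number, while the values of compound 1 and compound 2 are limits and not numbers: the limit of > 100000 nM in this assay, at which 2 of the 3 values shown sit.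

Since both steps start from a limit, their full size remains open, and the compounds shown cannot tell how much of the difference each of the two groups contributes on its own. Going by these compounds, it also remains open whether an ethyl group or a longer chain on the same nitrogen would lower the number further than methyl does, or whether a fluoro group in place of the methoxy would keep it.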